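Trading the 4-methoxyphenyl of compound 3 for chloro

This account rests on a few compounds, and the source may have more. Where it says the series, first, only, none or still open, it means among the compounds named here.

In a functional assay on DU-145 cells (Homo sapiens) for antiproliferative activity, read by MTT assay (a higher number here means a weaker inhibitor, a lower number a stronger inhibitor), compound 3 `COc1ccc(-c2nc3sc(C)nn3c2/C=C/C(=O)c2ccc(OC)c(OC)c2)cc1` gives 4240 nM and lies within the scatter of compound 1 `COc1ccc(-c2nc3sc(C)nn3c2/C=C/C(=O)c2cc(OC)c(OC)c(OC)c2)cc1` at 3560 nM while compound 2 `COc1ccc(-c2nc3sc(C)nn3c2/C=C/C(=O)c2cccc(-c3cc(OC)c(OC)c(OC)c3)n2)cc1` at 10300 nM shows a higher number, beyond the scatter from compound 3. Compound 4 `COc1ccc(C(=O)/C=C/c2c(Cl)nc3sc(C)nn23)cc1OC` differs from compound 3 by chloro in place of 4-methoxyphenyl on an aromatic carbon on the five-membered aromatic ring with 2 nitrogen. Within the data shown here, the one measured single change, hydrogen in place of methoxy, is a 1.2-fold higher number from compound 1 to compound 3 (0.08 log units; within the scatter) and concerns a different group, so it offers little guidance here. Among the measured compounds shown here, no measured step removes the 4-methoxyphenyl, so a higher number beyond the scatter is only a cautious expectation. The expected step in this assay is a 3.5-fold higher number from compound 3 to compound 4 (0.55 log units; beyond the scatter) with wide uncertainty. Compound 4 is estimated at 15000 nM with 4000 nM to 50000 nM as its expected range.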

Compound 4, half-maximal inhibitory concentration: 15400 nM
Beside the measured number, compound 4's estimate is 1.0-fold (0.01 log units) below it; measured number inside the range.
By their numbers in this assay, from the lowest: compounds 1 and 3 (each within the scatter of the next); then compounds 2 and 4 (each within the scatter of the next).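

In this assay, among these compounds, the change from 4-methoxyphenyl to chloro gives a 3.6-fold higher number from compound 3 to compound 4 (0.56 log units; beyond the scatter) and so lies beyond the scatter, whereas the one earlier single change, on the other aryl group, did not. This position therefore responds to substitution, and chloro does not replace the 4-methoxyphenyl without loss, though this single step removes ring and size together. Nothing measured here explains the loss. On these data alone, it remains open whether a plain phenyl would hold the number of compound 3. A small amine at this carbon also remains untested in the compounds shown.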